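The source may report more compounds than this note shows. Statements on the series, on what has been measured and on what is new or still open speak of the compounds shown alone.

Working notes on the series. Compound 3 `CC(C(=O)NCc1ccc(C(F)(F)F)cc1SC1CCCC1)c1ccc(NS(C)(=O)=O)c(F)c1` gives 0.3 nM in an assay on CHO cells for antagonist activity at transient receptor potential cation channel subfamily V member 1 (Homo sapiens), read by FLIPR (on this read-out higher numbers stand for weaker inhibition and lower numbers for stronger inhibition), the lowest number of the three measured compounds. Compound 1 `CC1CCN(c2cc(C(F)(F)F)ccc2CNC(=O)C(C)c2ccc(NS(C)(=O)=O)c(F)c2)CC1` gives 0.9 nM in this assay, and compound 2 `CC(C(=O)NCc1ccc(C(F)(F)F)cc1OC1CCCCC1)c1ccc(NS(C)(=O)=O)c(F)c1` gives 0.7 nM. The steps among them were modest: a 3.0-fold lower number from compound 1 to compound 3 (0.48 log units; beyond the scatter), and a 2.3-fold lower number from compound 2 to compound 3 (0.37 log units; beyond the scatter), while a 1.3-fold lower number from compound 1 to compound 2 (0.11 log units; within the scatter).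

Compound 4 `CC(C(=O)NCc1ccc(C(F)(F)F)cc1F)c1ccc(NS(C)(=O)=O)c(F)c1` has not yet been measured. It differs from compound 3 as follows: fluoro in place of cyclopentylsulfanyl on an aromatic carbon. Going by the values given here, none of the measured steps bears directly on this change; each of them swapped one ring-bearing group for another at that aromatic carbon, whereas here a group of six heavy atoms with a five-membered ring leaves and a single fluorine atom enters. Among the compounds with values here, the measured compounds therefore give no step of this kind to lean on, and the expectation must be wider than the observed scatter. The number for compound 4 in this assay is estimated to rise, with an expected step of a 50-fold higher number from compound 3 to compound 4 (1.70 log units; beyond the scatter). The value for compound 4 is estimated at 15 nM, within a range of 3 nM to 100 nM.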

Compound 4, inhibition constant: 68.7 nM
For compound 4 the middle estimate is 4.6-fold (0.66 log units) below the measured one, and the stated range covers the measured number.
By their numbers in this assay, from the lowest: compound 3; then compounds 2 and 1 (each within the scatter of the next); then compound 4.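

In this assay fluoro at this aromatic carbon gives a 230-fold higher number from compound 3 to compound 4 (2.36 log units; beyond the scatter) and a 98-fold higher number from compound 2 to compound 4 (1.99 log units; beyond the scatter) as well as a 76-fold higher number from compound 1 to compound 4 (1.88 log units; beyond the scatter) while the steps among compound 1, compound 2 and compound 3 were modest at most. The low numbers therefore hold across three ring-bearing groups attached through sulfur, oxygen or nitrogen, and do not survive the change to a single fluorine atom. No measurement at hand explains this loss.

On these data alone, whether the low numbers go with the ring itself or only with a larger group stays open, and an open-chain pentylsulfanyl group at this carbon would separate the two. A methoxy group or a cyclopropyloxy group would show how much of the cyclopentylsulfanyl group can be removed before the number rises.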